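The compounds below may be only part of what the source reports. "The series", "measured", "known", "first", "only" and "open" are said of these compounds alone.

Measured compounds in a functional assay on the whole organism (strain C57B/6) with Mus musculus as the target, in the maximal electroshock model; a lower number here means that less compound is needed, a higher number that more compound is needed for the effect:
compound 1 `CCCCCCOc1ccc(-n2cnnc2)cc1`, 9.8 mg/kg
compound 2 `CCCCCCOc1ccc(-n2cnnc2CCC)cc1`, 5.7 mg/kg
compound 3 `CCCCCCCc1nncn1-c1ccc(OCCCCCC)cc1`, a limit of the assay: > 40 mg/kg

Compound 3 sits at the limit of this assay (the limit of > 40 mg/kg in this assay, at which 1 of the 3 values shown sits), so only a bound and no number is known for it. Compound 4 `CCCCCCOc1ccc(-n2cnnc2-c2ccccc2F)cc1` is not yet measured; it differs from compound 3 by 2-fluorophenyl in place of heptyl on an aromatic carbon.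

The measured steps that bear on this change are those that vary the same carbon: a 1.7-fold lower number from compound 1 to compound 2 (0.24 log units; within the scatter) and an at least 4.0-fold higher number from compound 1 to compound 3 (0.61 log units; beyond the scatter), and between them an at least 7.0-fold higher number from compound 2 to compound 3 (0.84 log units; beyond the scatter). The propyl compound 2 stays close to compound 1, while the heptyl compound 3 falls beyond the limit. Among the compounds with values here, the 2-fluorophenyl group of compound 4 matches heptyl in heavy-atom count but is a ring rather than a chain; no measured compound carries an aromatic group at this position, so the direction of the step is uncertain. A lower number than the bound of compound 3 is expected for compound 4, that is an estimated step of an at least 2.0-fold lower number from compound 3 to compound 4 (0.30 log units; that floor lies within the scatter). The expected value for compound 4 in this assay is 20 mg/kg, with a range from 5 mg/kg to 60 mg/kg.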

Compound 4, dose for half-maximal effect: 20.2 mg/kg
The estimate for compound 4 lay 1.0-fold (0.00 log units) below the measured number, and the stated range covers the measured number.
By their numbers in this assay, from the lowest: compounds 2 and 1 (each within the scatter of the next); then compound 4. At a limit, above all of these: compound 3.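

In this assay, within the data shown here, compound 4 gives the first reading of an aromatic ring on this carbon, where the earlier compounds carry only hydrogen, propyl or heptyl. Replacing hydrogen with the ring gives a 2.1-fold higher number from compound 1 to compound 4 (0.31 log units; beyond the scatter) and replacing propyl with it gives a 3.5-fold higher number from compound 2 to compound 4 (0.55 log units; beyond the scatter), so 2-fluorophenyl is tolerated but falls behind both smaller substituents in this series. Compound 3 has only a limit of > 40 mg/kg and the step to the ring can be read only as a floor, an at least 1.9-fold lower number from compound 3 to compound 4 (0.29 log units; that floor lies within the scatter), leaving the true gap between heptyl and 2-fluorophenyl undefined: the limit of > 40 mg/kg in this assay, at which 1 of the 4 values shown sits.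

The compounds shown do not separate the contribution of the ring from that of its fluorine, which plain phenyl on this carbon would address. They also leave open where between propyl and heptyl the response changes, which a butyl or pentyl chain would help to locate.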